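This account rests on a few compounds, and the source may have more. Where it says the series, first, only, none or still open, it means among the compounds named here.

Working notes on the series.

Two cores are compared in a functional assay on T47D cells (Homo sapiens) for cytotoxicity, with a stated time of 72 h, tested at 10 ug/mL; on this read-out higher numbers stand for a stronger effect at the one concentration tested and lower numbers for a weaker effect. The first core is carried by compound 1 `Cc1ccc(N2CCN/C2=N\N)cc1` and compound 3 `N/N=C1\NCCN1c1ccccc1`; the second by compound 2 `Cc1ccc(N2CCn3c2n[nH]c(=O)c3=N)cc1` and the unmeasured compound 4 `N=c1c(=O)[nH]nc2n1CCN2c1ccccc1`. The difference between the two cores is not broken down here.

In this assay compound 1 gives 12%, compound 3 gives 0% and compound 2 gives 0%. Compound 2 and compound 3 stand level at the digits recorded, and together they sit lowest of the three numbers; compound 1 stands higher than compound 2 by a margin beyond the scatter.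

For the measured compounds named here, the one step measured within a core is a number 12 percentage points lower from compound 1 to compound 3 (beyond the scatter), made by hydrogen in place of methyl on an aromatic carbon. The same kind of change leads from compound 2 to compound 4: hydrogen in place of methyl on an aromatic carbon. The places are not described in the same words, the group being para to a group of 7 heavy atoms in the first core and para to a large group in the second, so the change counts as the same kind rather than the same.

On this assay a step of a number 2 percentage points higher from compound 2 to compound 4 (within the scatter) is expected from compound 2 to compound 4, beside the measured a number 12 percentage points lower from compound 1 to compound 3 (beyond the scatter); this rests on compound 2 already giving 0%, which leaves no room for a further fall of comparable size, and the change is not expected to raise the number. Compound 4 is accordingly estimated at 2%, in a range from 0% to 10%.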

Compound 4, a percentage reported as inhibition, at one concentration (the size of the read-out at that concentration, not a potency): 0%
Estimate against measurement, compound 4: 2 percentage points above, within the range that was stated.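

In this assay, hydrogen in place of methyl on an aromatic carbon reads no change at the digits printed from compound 2 to compound 4 (within the scatter) on the core of compound 2. Set beside the same kind of change on the core of compound 1, this result does not separate the two cores: the same change on two cores in this assay, a number 12 percentage points lower (beyond the scatter) from compound 1 to compound 3 and no change at the digits printed (within the scatter) from compound 2 to compound 4, 12 percentage points apart, within the scatter of two such steps. For the compounds shown here, this gives no sign that the change behaves differently from one core to the other, but neither does it show that the change carries across, as each core supplies only one pair and compound 2 already stands at 0%, which leaves no room for a fall to be seen on that core.

The compounds shown hold only methyl or hydrogen at this place on the six-membered aromatic ring, so it remains open how an amine, a carboxylic acid, a chlorine atom or a longer alkyl chain there would read in this assay on either core. Going by these compounds alone, also open is which part of the difference between the two cores bears on the read-out, as no pair here differs at only one place within that difference.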